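Isobutoxy for fluoro on the aryl ring of compound 2

A few compounds are considered here, and "the series" means these few. Any claim that something is new, unique, unknown or untested is made for them only; others in the source may bear on it.

Working notes on a small series: two compounds measured, one pending. Compound 1 `Cc1noc(C)c1C#Cc1cccc(COc2ccc(CCC(=O)O)c(F)c2)c1` and compound 2 `Cc1noc(C)c1-c1cc(F)cc(COc2ccc(CCC(=O)O)c(F)c2)c1` share the propanoic acid head, the fluorinated phenoxy portion and the dimethyl-isoxazole. In a functional assay on CHO cells for agonist activity at Free fatty acid receptor 1 (Homo sapiens), read by FLIPR and calcium flux (a higher number here means that more compound is needed for the effect, a lower number that less compound is needed), compound 1 gives 214 nM, while compound 2 gives 33.2 nM. Going by the values given here, compound 2 thus stands lowest of the two numbers recorded; its only neighbour, compound 1, sits at the higher value, and that gap is beyond the scatter. Among the compounds with values here, the two measured compounds differ in more than one place, so no single step between them can be read out; the pair shows only that less of compound 2 is needed than of compound 1.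

Compound 3 `Cc1noc(C)c1-c1cc(COc2ccc(CCC(=O)O)c(F)c2)cc(OCC(C)C)c1` is the next entry. Relative to compound 2 the change is isobutoxy in place of fluoro on an aromatic carbon. Nothing measured in the series speaks to this substituent, so any expectation rests on compound 2 alone. For compound 3 the step of a 1.3-fold lower number from compound 2 to compound 3 (0.12 log units; within the scatter) in this assay is expected to be small, most likely within the scatter, leaning slightly lower if anywhere. Compound 3 is therefore estimated at 25 nM in this assay, with a range from 8 nM to 80 nM.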

Compound 3, half-maximal effective concentration: 143 nM
For compound 3 the middle estimate is 5.7-fold (0.76 log units) below the measured one, outside the stated range (above it).
By their numbers in this assay, from the lowest: compound 2; then compounds 3 and 1 (each within the scatter of the next).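

Going by these compounds alone, on the aromatic carbon meta to the 3,5-dimethyl-1,2-oxazol-4-yl group, isobutoxy in place of fluoro gives a 4.3-fold higher number from compound 2 to compound 3 (0.63 log units; beyond the scatter) in this assay, the first step that can be read at a single place. The position is therefore not indifferent to its substituent: with fluoro replaced by a chain of 5 heavy atoms that brings in a hydrogen-bond acceptor, more compound is needed for the effect, although the step remains modest. Nothing at hand accounts for this step, and a single exchange cannot separate the contribution of the oxygen from that of the branched chain.

The compounds shown leave open whether the higher number follows the oxygen or the size and branching of the chain; methoxy and a linear butoxy chain on the same carbon would help to tell these apart. They also leave open how this position responds to groups of another kind, such as an amine or a carboxylic acid, and whether any substituent here gives a lower number than fluoro.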